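The source may hold more compounds than are shown below. What is called first, only, known or untested is meant among the compounds shown, and "the series" means these compounds.

Measured in an ADME assay on A549 cells (Homo sapiens) for cytotoxicity, read by resazurin assay, with a stated time of 48 h; on this read-out lower numbers stand for higher toxicity in this test and higher numbers for lower toxicity in this test:
- compound 1 `CC(C)Nc1ccc(NC(=O)c2cc(Cl)ccc2O)c(Cl)c1` gives 11000 nM
- compound 2 `O=C(Nc1ccc(NCCCO)cc1Cl)c1cc(Cl)ccc1O` gives 106000 nM

Compound 2 stands highest of the two measured compounds, at 106000 nM. Compound 3 `O=C(Nc1ccc(N(CCCO)CCCO)cc1Cl)c1cc(Cl)ccc1O` differs from it by 3-hydroxypropyl in place of hydrogen on a nitrogen on an aromatic ring, with 3-hydroxypropyl in place of hydrogen on a nitrogen on an aromatic ring. Among the measured compounds shown here, only one measured step bears on this, a 9.6-fold higher number from compound 1 to compound 2 (0.98 log units; beyond the scatter), which also brought 3-hydroxypropyl onto that nitrogen. From that single step, a smaller move in the same direction is expected in this assay. The expected change is a 1.5-fold higher number from compound 2 to compound 3 (0.18 log units; within the scatter). The estimate for compound 3 is 160000 nM, within a range of 65000 nM to 380000 nM.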

Compound 3, half-maximal cytotoxic concentration: 114000 nM
Estimate against measurement, compound 3: 1.4-fold (0.15 log units) above, within the range that was stated.
By their numbers in this assay, from the lowest: compound 1; then compounds 2 and 3 (each within the scatter of the next).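

In this assay, a second 3-hydroxypropyl on the nitrogen gives a 1.1-fold higher number from compound 2 to compound 3 (0.03 log units; within the scatter), so compound 2 and compound 3 cannot be told apart. Bis(3-hydroxypropyl)amino in place of isopropylamino gives a 10-fold higher number from compound 1 to compound 3 (1.02 log units; beyond the scatter), so the gap from compound 1 stands with one 3-hydroxypropyl or with two. No available evidence accounts for this result. The compounds shown leave open whether a longer chain, or a chain ending in an amine or a carboxylic acid, on this nitrogen would give a number in the same range.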